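Working notes: from compound 3 to compound 4

The source may hold more compounds than are shown below. What is called first, only, known or untested is meant among the compounds shown, and "the series" means these compounds.

- compound 1 `CCCCCCNc1nc2cc(-c3ccc(C)cc3)sc2c(=O)[nH]1` in an ADME assay on HepG2 cells (Homo sapiens) for cytotoxicity, read by MTT assay, with a stated time of 72 h (a lower number here means that less compound is tolerated, a higher number that more compound is tolerated), gives 10600 nM
- compound 2 `Cc1ccc(-c2cc3nc(NCC(C)C)[nH]c(=O)c3s2)cc1` in this assay gives 21600 nM
- compound 3 `CCCCCCC(C)Nc1nc2cc(-c3ccc(C)cc3)sc2c(=O)[nH]1` in this assay gives 19400 nM

Compound 3, at 19400 nM, lies within the scatter of both other compounds, so it has no separate rank among the three numbers. Only compound 1 and compound 2 are separated, and only just.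

Compound 4 `Cc1ccc(-c2cc3nc(NCc4ccccc4Cl)[nH]c(=O)c3s2)cc1` is not yet measured. Its change from compound 3 is 2-chlorobenzyl in place of 1-methylheptyl on a nitrogen on an aromatic ring.

The measured steps all alter the substituent at this same place. They are a 2.0-fold higher number from compound 1 to compound 2 (0.31 log units; beyond the scatter), a 1.8-fold higher number from compound 1 to compound 3 (0.26 log units; within the scatter) and a 1.1-fold lower number from compound 2 to compound 3 (0.05 log units; within the scatter). All three are small: the first falls just beyond the scatter and the other two within it. However, none of the measured compounds has a ring in this substituent, so the data do not cover that feature directly and the range is kept wide.

In this assay no step beyond the scatter is expected, and no direction is favoured. The estimated step is a 1.2-fold lower number from compound 3 to compound 4 (0.08 log units; within the scatter). Compound 4 is expected at 16000 nM, with an estimated range of 7000 nM to 34000 nM.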

Compound 4, half-maximal cytotoxic concentration: 32600 nM
Compound 4: the middle estimate sits 2.0-fold (0.31 log units) below what was measured; the measured number falls inside the stated range.
By their numbers in this assay, from the lowest: compounds 1, 3, 2 and 4 (each within the scatter of the next, the first and the last beyond it).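

In this assay, among these compounds, the 2-chlorobenzyl group is the first substituent on this nitrogen to carry a six-membered aromatic ring, and it stays within the scatter of two of the open chains (a 1.7-fold higher number from compound 3 to compound 4 (0.23 log units; within the scatter); a 1.5-fold higher number from compound 2 to compound 4 (0.18 log units; within the scatter)). Only the hexyl compound is separated from it (a 3.1-fold higher number from compound 1 to compound 4 (0.49 log units; beyond the scatter)), and this is the largest step in the set so far and still a modest one, so the whole span at this position remains narrow across branched chains, a straight chain and a ring-bearing group. Nothing available bears on the reason for this tolerance of the ring.

Going by these compounds, it remains open what the chlorine contributes beyond the ring itself, and how a benzyl group without chlorine, a cyclohexylmethyl group, or a chain ending in an amine or a carboxylic acid would behave on this nitrogen. On these data alone, it is also open whether so narrow a span would persist if the shared core were changed.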